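The source may report more compounds than this note shows. Statements on the series, on what has been measured and on what is new or still open speak of the compounds shown alone.

Working notes on the series. The set comprises compound 1 `COc1ccc(CN(C(=O)Nc2ccc(Cl)cc2)n2cnnc2)cc1OC`, compound 2 `COc1ccc(CN(C(=O)Nc2ccc(F)c(Cl)c2)n2cnnc2)cc1OC`, compound 3 `COc1ccc(CN(C(=O)Nc2ccc(Cl)c(C(F)(F)F)c2)n2cnnc2)cc1OC` and the unmeasured compound 4 `Cc1ccsc1CN(C(=O)Nc1ccc(Cl)c(C(F)(F)F)c1)n1cnnc1`. In a functional assay on MDA-MB-231 cells (Homo sapiens) for cytotoxicity, read by MTT assay, with a stated time of 48 h (on this read-out lower numbers stand for stronger inhibition and higher numbers for weaker inhibition), compound 1 reaches only the limit > 50000 nM. In the same this assay compound 2 gives 27900 nM. Compound 3 also sits at the limit > 50000 nM. Two of the three values shown therefore rest at the same floor (the limit of > 50000 nM in this assay, at which 2 of the 3 values shown sit), so compound 3 stands no better than the weak end of what is visible. For the measured compounds named here, the step of an at least 1.7-fold lower number from compound 1 to compound 2 (0.25 log units; that floor lies within the scatter) is the only measured change that moves a number, and the step that the two limits leave unreadable from compound 1 to compound 3 cannot be read at all.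

The change to compound 4 is 3-methylthiophen-2-yl in place of 3,4-dimethoxyphenyl on a saturated chain carbon bound to an amide-type nitrogen. Going by the values given here, no measured step touches this part of the molecule, so there is nothing to set a size or direction for this assay beyond the scatter. The expected result for compound 4 is 50000 nM, with a range from 20000 nM to 150000 nM. This estimate corresponds to a number no higher from compound 3 to compound 4 (the limit leaves the size open), with a limit again the most likely report.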

Compound 4, half-maximal inhibitory concentration: 29600 nM
Beside the measured number, compound 4's estimate is 1.7-fold (0.23 log units) above it; the range from low to high includes it.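

For the compounds shown here, this is the first measured change on the saturated chain carbon bound to an amide-type nitrogen, and it gives a readable number in this assay: an at least 1.6-fold lower number from compound 3 to compound 4 (0.22 log units; that floor lies within the scatter). On these data alone, the 3,4-dimethoxyphenyl group is therefore not needed for a number to appear, though the floor of the step lies within the scatter and its true size stays open. Compound 3 itself holds only a limit, which frames the reading: the limit of > 50000 nM in this assay, at which 2 of the 4 values shown sit.

As far as these compounds go, the step from compound 1 to compound 3 cannot be read, and whether 3-methylthiophen-2-yl acts alike alongside the 3-chloro-4-fluorophenyl group of compound 2 stays open. Also open, from the compounds shown here alone, is how an unsubstituted phenyl, a pyridine ring or a thiophene without its methyl would read at this carbon.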